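This account rests on a few compounds, and the source may have more. Where it says the series, first, only, none or still open, it means among the compounds named here.

For the measured compounds named here, compound 1 `CCN(CC)CN1C(=O)/C(=N/NC(N)=S)c2cc(Cl)ccc21` gives 44000 nM in a functional assay on HeLa cells (Homo sapiens) for inhibition, read by cell counting, with a stated time of 96 h (a lower number here means a stronger inhibitor, a higher number a weaker inhibitor), the lowest of the two numbers so far. Going by the values given here, compound 2 `CCN(CC)CN1C(=O)/C(=N/NC(N)=S)c2ccccc21` gives 123000 nM in this assay, and the one measured step, a 2.8-fold higher number from compound 1 to compound 2 (0.45 log units; beyond the scatter), concerns the aromatic chloro only. Compound 3 `CCN(CC)CN1C(=O)/C(=N/NC(=S)Nc2ccc(Cl)cc2)c2cc(Cl)ccc21` differs from compound 1 by 4-chlorophenyl in place of hydrogen on an amide-type nitrogen. Among the compounds with values here, no measured step touches the amide-type nitrogen, so nothing speaks to this change. The expected step for compound 3 is a 1.8-fold lower number from compound 1 to compound 3 (0.25 log units; within the scatter), hardly beyond the scatter. The estimate for compound 3 is therefore 25000 nM, within a range from 5000 nM to 120000 nM.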

Compound 3, half-maximal inhibitory concentration: > 125000 nM
Compound 3: a limit, no number; the forecaster's own chance of this, stated with the estimate: 5%; middle value at least 5.0-fold (0.69 log units) from the limit.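

The amide-type nitrogen is now shown to matter: with 4-chlorophenyl in place of hydrogen, the step is an at least 2.8-fold higher number from compound 1 to compound 3 (0.45 log units; beyond the scatter). Compound 3 gives > 125000 nM in this assay, which is a limit of the assay and not a number. The change therefore raises the number rather than lowering it, but its full size cannot be read: the limit of > 125000 nM in this assay, at which 1 of the 3 values shown sits.

Open, on these data alone, is whether methyl or unsubstituted phenyl on this nitrogen would keep the number close to that of compound 1. Also open, as far as these compounds go, is whether the chlorine of the 4-chlorophenyl or its ring carries the step.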